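Pyrazole amide replacing the N-phenyl group on the piperidine

The source may hold more compounds than are shown below. What is called first, only, known or untested is meant among the compounds shown, and "the series" means these compounds.

Measured compounds:
- compound 1, `O=C(C1CCN(C(=O)C(F)(F)F)CC1)N1N=CCC1c1ccccc1`: 4.9
- compound 2, `CCC(=O)N1CCC(C(=O)N2N=CCC2c2ccccc2)CC1`: 3.2
- compound 3, `O=C(C1CCN(c2ccccc2)CC1)N1N=CCC1c1ccccc1`: 6.3

In a physicochemical assay for lipophilicity, read by HPLC, measured as chromatographic lipophilicity, at pH 7.4 (a higher number here means a more lipophilic compound, a lower number a more polar compound), compound 3 gives the highest of the three numbers, 6.3. Its nearest neighbour is compound 1, a number 1.40 log units higher from compound 1 to compound 3 (beyond the scatter), and the furthest is compound 2, a number 3.10 log units higher from compound 2 to compound 3 (beyond the scatter). Compound 4, `O=C(c1cc[nH]n1)N1CCC(C(=O)N2N=CCC2c2ccccc2)CC1`, has not yet been measured in this assay. It differs from compound 3 in one place: (1H-pyrazol-3-yl)carbonyl in place of phenyl on an amine nitrogen in a ring. Among the compounds with values here, two measured steps bear directly on this change, since both replace an acyl group on the same ring nitrogen with phenyl: a number 3.10 log units higher from compound 2 to compound 3 (beyond the scatter) and a number 1.40 log units higher from compound 1 to compound 3 (beyond the scatter). Compound 4 moves the other way, from phenyl back to an acyl group, and the group that enters carries a hydrogen-bond donor and two acceptors that the propanoyl of compound 2 does not. Within the data shown here, a large downward step is therefore expected, at least as large as the one between compound 2 and compound 3. Compound 4 is estimated at 2.8, within 2 to 3.6, which would mean an expected step of a number 3.50 log units lower from compound 3 to compound 4 (beyond the scatter).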

Compound 4, distribution coefficient: 2.4
Compound 4: the middle estimate sits 0.40 log units above what was measured; the measured number falls inside the stated range.
By their numbers in this assay, from the lowest: compound 4; then compound 2; then compound 1; then compound 3.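

In this assay, the (1H-pyrazol-3-yl)carbonyl group on the amine nitrogen of the ring gives the lowest number of the four compounds, and replacing phenyl with it produces the largest step yet seen at this position, a number 3.90 log units lower from compound 3 to compound 4 (beyond the scatter). The earlier compounds shown here compared only small acyl groups with phenyl, whereas this result shows that an acyl group bearing an aromatic ring also falls well below phenyl and even below both small acyl groups, with a number 0.80 log units lower from compound 2 to compound 4 (beyond the scatter) and a number 2.50 log units lower from compound 1 to compound 4 (beyond the scatter). The data offer no measured explanation for this order.

As far as these compounds go, it remains open how much of the fall belongs to the carbonyl and how much to the hetero atoms of the ring, a question that a benzoyl group on the same nitrogen could address. A methyl group on the pyrazole nitrogen could likewise test what the hydrogen-bond donor contributes.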